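A few compounds are considered here, and "the series" means these few. Any claim that something is new, unique, unknown or untested is made for them only; others in the source may bear on it.

Measured compounds:
- compound 1 `CCCCCCCCc1cn([C@H]2C[C@H](O)[C@@H](CO)O2)c(=O)[nH]c1=O`: in a functional assay on L1210 cells (Mus musculus) (a higher number here means a weaker inhibitor, a lower number a stronger inhibitor), compound 1 gives 72 ug/mL.
- compound 2 `CCCc1cn([C@H]2C[C@@H]3OP(=O)(O)OC[C@H]3O2)c(=O)[nH]c1=O`: compound 2 gives only a limit, > 500 ug/mL.
- compound 3 `CC(C)c1cn([C@H]2C[C@@H]3OP(=O)(O)OC[C@H]3O2)c(=O)[nH]c1=O`: compound 3 gives only a limit, > 500 ug/mL.

Within the data shown here, compound 1 holds the only number in the set; the other two values are limits, (the limit of > 500 ug/mL in this assay, at which 2 of the 3 values shown sit). Among the measured compounds shown here, the one step between measured compounds, a step that the two limits leave unreadable from compound 2 to compound 3, is unreadable from its two limits and concerns the sugar-locked pair, not compound 1.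

Compound 4 `CCCc1cn([C@H]2C[C@H](O)[C@@H](CO)O2)c(=O)[nH]c1=O` differs from compound 1 by hydrogen in place of pentyl on a saturated chain carbon, three bonds along the chain from an aromatic carbon. For the measured compounds named here, no measured step covers this change on the core of compound 1. Compound 2 carries the propyl group on a different sugar and reaches only a limit, so the expectation for compound 4 is a weaker value, the step of a 4.2-fold higher number from compound 1 to compound 4 (0.62 log units; beyond the scatter) being estimated. Compound 4 is expected near 300 ug/mL, within 80 ug/mL to 1000 ug/mL.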

Compound 4, concentration for 50% inhibition: > 500 ug/mL
Compound 4 ended at the assay's limit; the forecaster's own chance of this, stated with the estimate: 40%; at least 1.6-fold (0.22 log units) between middle value and limit.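

Notes on the chain at this position: on the core of compound 1, going from octyl to propyl, with hydrogen in place of pentyl on a saturated chain carbon, three bonds along the chain from an aromatic carbon, gives an at least 6.9-fold higher number from compound 1 to compound 4 (0.84 log units; beyond the scatter) in this assay. Among these compounds, this is the first readable step in the set, and the earlier compounds offered no pair on this core. Compound 4 gives a limit of the assay, not a number: the limit of > 500 ug/mL in this assay, at which 3 of the 4 values shown sit.

As far as these compounds go, how far the step extends stays open, and one pair gives no trend with chain length. From the compounds shown here alone, what a decyl chain, or a hexyl chain ending in an amine or a carboxylic acid, would give on this core also stays open.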